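The source may hold more compounds than are shown below. What is called first, only, known or untested is meant among the compounds shown, and "the series" means these compounds.

Of the compounds shown here, three sharing one core have been measured in an ADME assay on MDCKII-LE cells (Canis lupus familiaris) for permeability; a lower number here means that the compound crosses the layer more slowly, a higher number that the compound crosses the layer faster. Compound 1 (`Cc1cnc(NC(=O)c2cc(Oc3cnc(C(=O)N(C)C)cn3)c3cc(C)oc3c2)cn1`) gives 22.3 10^-6 cm/s, compound 2 (`CCN(C)C(=O)c1cnc(Oc2cc(C(=O)Nc3cnc(C)cn3)cc3oc(C)cc23)cn1`) gives 24.1 10^-6 cm/s and compound 3 (`CNC(=O)c1cnc(Oc2cc(C(=O)Nc3cnc(C)cn3)cc3oc(C)cc23)cn1`) gives 20.9 10^-6 cm/s. Compound 3 therefore stands level with the other two, within the usual scatter of repeat measurements. The next compound, compound 4 (`Cc1cnc(NC(=O)c2cc(Oc3cnc(C(=O)N4CCC4)cn3)c3cc(C)oc3c2)cn1`), differs from compound 3 by azetidin-1-yl in place of methylamino on a carbonyl carbon. The closest evidence comes from changes on the amide-type nitrogen. Hydrogen in place of methyl gave a 1.1-fold lower number from compound 1 to compound 3 (0.03 log units; within the scatter), hydrogen in place of ethyl gave a 1.2-fold lower number from compound 2 to compound 3 (0.06 log units; within the scatter), and the reverse kind of growth, methyl in place of hydrogen on the chain, gave a 1.1-fold higher number from compound 1 to compound 2 (0.03 log units; within the scatter). For the measured compounds named here, all three steps stayed within the scatter, although no measured compound carries the four-membered ring. No step beyond the scatter is therefore expected in this assay. The estimated step is a 1.1-fold higher number from compound 3 to compound 4 (0.04 log units; within the scatter). For compound 4 the estimated value is 23 10^-6 cm/s, with an expected range of 15 10^-6 cm/s to 33 10^-6 cm/s.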

Compound 4, apparent permeability: 17.4 10^-6 cm/s
Estimate against measurement, compound 4: 1.3-fold (0.12 log units) above; measured number inside the range.
By their numbers in this assay, from the lowest: compounds 4, 3, 1 and 2 (each within the scatter of the next).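

For the compounds shown here, compound 4 brings a ring onto this carbonyl carbon for the first time, and in this assay the swap still leaves the number level with those of all three open-chain amides: azetidin-1-yl in place of methylamino gives a 1.2-fold lower number from compound 3 to compound 4 (0.08 log units; within the scatter), in place of dimethylamino a 1.3-fold lower number from compound 1 to compound 4 (0.11 log units; within the scatter), and in place of ethyl(methyl)amino a 1.4-fold lower number from compound 2 to compound 4 (0.14 log units; within the scatter). Across these four compounds, then, neither the four-membered ring nor the presence of the hydrogen-bond donor in methylamino separates the numbers beyond the scatter. Nothing available here speaks to the mechanism behind these numbers.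

As far as these compounds go, whether this flat picture holds for a larger ring such as piperidin-1-yl or morpholin-4-yl remains open. The same goes for a chain ending in an amine or a carboxylic acid on this carbonyl carbon.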